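From an aminoethyl amide to a carboxy-bearing side chain

The source may report more compounds than this note shows. Statements on the series, on what has been measured and on what is new or still open speak of the compounds shown alone.

Within the data shown here, in an ADME assay on L02 cells (Homo sapiens) for cytotoxicity, read by MTT assay, with a stated time of 48 h (on this read-out higher numbers stand for weaker inhibition and lower numbers for stronger inhibition), compound 1 `CCN(CC)CCNC(=O)c1ccc(C(CC)(CC)c2ccc(OCC(=O)C(C)(C)C)c(C)c2)n1CC` gives 2500 nM and compound 2 `CCn1c(C(=O)NCCN)ccc1C(CC)(CC)c1ccc(OCC(=O)C(C)(C)C)c(C)c1` gives 2500 nM, so compound 2 stands level with its only measured neighbour. Among the measured compounds shown here, the single measured step, amino in place of diethylamino on a saturated chain carbon, is no change at the digits printed from compound 1 to compound 2 (within the scatter). Compound 3 `CC[C@@H](C)[C@H](NC(=O)c1ccc(C(CC)(CC)c2ccc(OCC(=O)C(C)(C)C)c(C)c2)n1CC)C(=O)O` brings a larger change: 1-carboxy-2-methylbutyl in place of 2-aminoethyl on an amide-type nitrogen. For the measured compounds named here, the earlier step altered only the amino group, while here the whole 2-aminoethyl group leaves, and no measured compound carries a carboxy group. Going by the values given here, that step is therefore weak guidance, but it is the only guidance available, and it points to no movement in either direction beyond the scatter. The expected step is a 1.2-fold higher number from compound 2 to compound 3 (0.08 log units; within the scatter). For compound 3 the estimated value is 3000 nM, with an expected range of 1000 nM to 10000 nM.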

Compound 3, half-maximal inhibitory concentration: 1500 nM
For compound 3 the middle estimate is 2.0-fold (0.30 log units) above the measured one; measured number inside the range.
By their numbers in this assay, from the lowest: compounds 3, 1 and 2 (each within the scatter of the next).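

In this assay, putting 1-carboxy-2-methylbutyl in place of 2-aminoethyl on the amide-type nitrogen gives a 1.7-fold lower number from compound 2 to compound 3 (0.22 log units; within the scatter) and putting it in place of 2-(diethylamino)ethyl gives a 1.7-fold lower number from compound 1 to compound 3 (0.22 log units; within the scatter) as the second step. Among these compounds, this shows that the position, until now seen only with chains ending in an amine, also accepts a side chain bearing a carboxy group and two defined stereocentres with no step beyond the scatter on this read-out. No supporting measurement is available to explain this result.

Whether a shorter carboxymethyl group, or a methyl ester in place of the carboxy group, would stay within the scatter of these compounds remains open. So does whether the mirror-image arrangement at the two stereocentres would read the same.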